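Pyridin-3-yl for thiophen-3-yl, carried to a second core

A few compounds are considered here, and "the series" means these few. Any claim that something is new, unique, unknown or untested is made for them only; others in the source may bear on it.

Measured so far in a functional assay on Huh-7 cells (Homo sapiens) for inhibition, read by sulforhodamine B assay, with a stated time of 72 h; a lower number here means a stronger inhibitor, a higher number a weaker inhibitor:
compound 1, `COc1cc(C(=O)/C=C/c2cn(-c3ccccc3)nc2-c2ccsc2)cc(OC)c1OC`: 3600 nM
compound 2, `COc1cc(OC)c(C(=O)/C=C/c2cn(-c3ccccc3)nc2-c2ccsc2)c(OC)c1`: 6100 nM
compound 3, `COc1cc(C(=O)/C=C/c2cn(-c3ccccc3)nc2-c2cccnc2)cc(OC)c1OC`: 1900 nM

Compound 1 and compound 3 share one core and differ by pyridin-3-yl in place of thiophen-3-yl on an aromatic carbon; this change gave a 1.9-fold lower number from compound 1 to compound 3 (0.28 log units; within the scatter). Compound 2 carries the other core, built from the same atoms as compound 1 joined differently; the difference between the two cores is not broken down here. In this assay compound 2 stands at the highest of the three numbers, yet its value and that of compound 1 lie within the scatter of each other, so no order between them is claimed. Against compound 3 the gap from compound 2 is beyond the scatter.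

Compound 4, `COc1cc(OC)c(C(=O)/C=C/c2cn(-c3ccccc3)nc2-c2cccnc2)c(OC)c1`, is not yet measured. It differs from compound 2 by pyridin-3-yl in place of thiophen-3-yl on an aromatic carbon, and the place of this change is the same, word for word, as in the pair compound 1 to compound 3, so it is the same change on the second core. Within the data shown here, the only measured example of this change is the single step on the first core, within the scatter, so the expectation rests on one pair only.

For compound 4 the expected step is a 1.8-fold lower number from compound 2 to compound 4 (0.27 log units; within the scatter), because the same change gave a 1.9-fold lower number from compound 1 to compound 3 (0.28 log units; within the scatter). Compound 4 is therefore estimated at 3300 nM in this assay, with a range from 1500 nM to 7000 nM.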

Compound 4, half-maximal inhibitory concentration: 500 nM
For compound 4 the middle estimate is 6.6-fold (0.82 log units) above the measured one, and the stated range ends above it.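

In this assay pyridin-3-yl in place of thiophen-3-yl gave a 12-fold lower number from compound 2 to compound 4 (1.09 log units; beyond the scatter) on the second core, a large step that is beyond the scatter. The size of this change therefore did not carry from one core to the other, and the step on the first core was a poor guide to the step on the second: the same change on two cores in this assay, a 1.9-fold lower number (0.28 log units; within the scatter) from compound 1 to compound 3 and a 12-fold lower number (1.09 log units; beyond the scatter) from compound 2 to compound 4, 6.4-fold (0.81 log units) apart, beyond the scatter of two such steps. Both steps point towards a lower number, but the step on the first core lies within the scatter, and two pairs neither explain why the cores differ nor support a rule for any further core.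

The compounds shown leave open whether the dependence on the core also holds for other groups at this place, on an aromatic carbon of the five-membered aromatic ring with 2 nitrogen, such as an amine or a carboxylic acid, and whether it survives when the phenyl group is exchanged for a longer chain. They also leave open whether the gap between the two steps would appear in another cell line or with another read-out.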